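Swapping a benzyloxy group for chlorine in a TRPV1 antagonist

The compounds below may be only part of what the source reports. "The series", "measured", "known", "first", "only" and "open" are said of these compounds alone.

The measured compounds and their values:
compound 1 `CC(C(=O)NCc1ccc(C(F)(F)F)cc1N1CCCC1)c1ccc(NS(C)(=O)=O)c(F)c1` gives 2.3 nM
compound 2 `CC(C)CCOc1cc(C(F)(F)F)ccc1CNC(=O)C(C)c1ccc(NS(C)(=O)=O)c(F)c1` gives 0.5 nM
compound 3 `CC(C(=O)NCc1ccc(C(F)(F)F)cc1OCc1ccccc1)c1ccc(NS(C)(=O)=O)c(F)c1` gives 0.9 nM

These three share a core and differ only in the group placed on one aromatic carbon. In an assay on CHO cells for antagonist activity at transient receptor potential cation channel subfamily V member 1 (Homo sapiens), read by FLIPR (on this read-out higher numbers stand for weaker inhibition and lower numbers for stronger inhibition), compound 3 stands second of the three numbers; its nearest neighbour is compound 2, and the gap between them is within the scatter, while compound 1 sits further away with a 2.6-fold lower number from compound 1 to compound 3 (0.41 log units; beyond the scatter) separating them.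

Compound 4 `CC(C(=O)NCc1ccc(C(F)(F)F)cc1Cl)c1ccc(NS(C)(=O)=O)c(F)c1` carries a much smaller group at that position: chloro in place of benzyloxy on an aromatic carbon. The chloro group sits on an aromatic carbon of a six-membered aromatic ring of carbon only, ortho to a large group and meta to a trifluoromethyl group.

Among the compounds with values here, no measured step directly tests a chloro group. The steps that touch this position, a 4.6-fold lower number from compound 1 to compound 2 (0.66 log units; beyond the scatter) and a 2.6-fold lower number from compound 1 to compound 3 (0.41 log units; beyond the scatter), show that the two oxygen-linked groups gave lower numbers than pyrrolidin-1-yl, while a 1.8-fold higher number from compound 2 to compound 3 (0.26 log units; within the scatter) shows the two oxygen-linked groups alike. Chlorine removes the oxygen and most of the bulk, so compound 4 is expected to give a somewhat higher number, a 3.3-fold higher number from compound 3 to compound 4 (0.52 log units; beyond the scatter), an estimated 3 nM with a range of 1 nM to 10 nM.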

Compound 4, inhibition constant: 4 nM
Estimate against measurement, compound 4: 1.3-fold (0.12 log units) below, and the stated range covers the measured number.
By their numbers in this assay, from the lowest: compounds 2 and 3 (each within the scatter of the next); then compounds 1 and 4 (each within the scatter of the next).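

In this assay, chloro gives a 4.4-fold higher number from compound 3 to compound 4 (0.65 log units; beyond the scatter) and an 8.0-fold higher number from compound 2 to compound 4 (0.90 log units; beyond the scatter), so at this aromatic carbon the benzyloxy and isopentyloxy groups each hold a lower number than a single chlorine atom. That does not make larger groups better across the board: pyrrolidin-1-yl goes against such a pattern, since a 1.7-fold higher number from compound 1 to compound 4 (0.24 log units; within the scatter) leaves it and chloro level within the scatter. Nothing available here explains these differences.

The compounds shown leave open whether the lower numbers go with the oxygen link or with the chain and ring beyond it. A methoxy group, which keeps the oxygen with only one carbon, and a pentyl chain, which keeps the length without the oxygen, would help to separate the two.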